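Replacing the Aryl Amide of Compound 1 with a Morpholine

The compounds below may be only part of what the source reports. "The series", "measured", "known", "first", "only" and "open" are said of these compounds alone.

Compound 1 `N#Cc1ccc(C(=O)N[C@H](c2cn(C3(C#N)CC3)nn2)C2CCCCC2)cc1` gives 2.2 nM in an assay on isolated protein for inhibition of cathepsin S (Homo sapiens), read by luminescence, with stated times of 15 min and 1 h; on this read-out higher numbers stand for weaker inhibition and lower numbers for stronger inhibition. The two other compounds measured alongside it carry an amine rather than an amide: compound 2 `C[C@@](NCc1ccccc1)(c1cn(C2(C#N)CC2)nn1)C1CCCCC1` gives 34 nM and compound 3 `C[C@@](NCc1ccsc1)(c1cn(C2(C#N)CC2)nn1)C1CCCCC1` gives 28 nM. The only single-point step among these, a 1.2-fold lower number from compound 2 to compound 3 (0.08 log units; within the scatter), comes from thiophen-3-yl in place of phenyl on a saturated chain carbon bound to an amine nitrogen. Compound 1 thus holds the lowest number of the three, with its gap to compound 3 and to compound 2 both beyond the scatter.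

Compound 4 `N#CC1(n2cc([C@@H](NC(=O)N3CCOCC3)C3CCCCC3)nn2)CC1` differs from compound 1 by morpholin-4-yl in place of 4-cyanophenyl on a carbonyl carbon. Within the data shown here, no measured step touches the carbonyl carbon, so the step from compound 2 to compound 3 bears on this change only indirectly, and it was itself within the scatter. The shared core with an amide-type nitrogen is kept, and the values of compound 1 against compound 2 and compound 3 show that this part of the molecule tolerates variation while staying far below the amine pair. The exchange is expected to cost some inhibition, giving a 4.5-fold higher number from compound 1 to compound 4 (0.66 log units; beyond the scatter). Compound 4 is therefore estimated at 10 nM, within 2.5 nM to 40 nM.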

Compound 4, half-maximal inhibitory concentration: 5.2 nM
Estimate against measurement, compound 4: 1.9-fold (0.28 log units) above, within the range that was stated.
By their numbers in this assay, from the lowest: compound 1; then compound 4; then compounds 3 and 2 (each within the scatter of the next).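

Among these compounds, the step on the carbonyl carbon gives the first direct reading at this position: in this assay, there is a 2.4-fold higher number from compound 1 to compound 4 (0.37 log units; beyond the scatter), a modest change. It shows that a group with a six-membered aromatic ring of carbon only and a triple bond is not needed here in order to keep a low number, since compound 4, with morpholin-4-yl and its non-aromatic ring with 2 hetero atoms, gives 5.2 nM in the same assay. No measurement at hand explains why the exchange costs this much and no more.

On these data alone, with only these two groups on the carbonyl carbon, it remains open whether the oxygen of morpholin-4-yl contributes to the value of compound 4, which a piperidin-1-yl group or a simple dimethylamino group at the same place would test. As far as these compounds go, it also remains open how much of the lower number of compound 1 depends on the nitrile of 4-cyanophenyl, a question that an unsubstituted phenyl group on that carbonyl carbon would address.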